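This account rests on a few compounds, and the source may have more. Where it says the series, first, only, none or still open, it means among the compounds named here.

Compound 1 `O=C(CSc1nnc(-c2ccncc2)n1-c1ccccc1)N/N=C/c1ccc(Br)cc1` gives 5990 nM in a functional assay on HepG2 cells (Homo sapiens) for inhibition, read by MTT assay, with a stated time of 48 h; a higher number here means a weaker inhibitor, a lower number a stronger inhibitor. Compound 2 `O=C(CSc1nnc(-c2ccncc2)n1-c1ccccc1)N/N=C/c1ccccc1F` gives 15200 nM. Compound 3 `O=C(CSc1nnc(-c2ccncc2)n1-c1ccccc1)N/N=C/c1cccc(F)c1` gives 24400 nM.

The gap a 1.6-fold higher number from compound 2 to compound 3 (0.21 log units; within the scatter) is within the scatter, whereas a 4.1-fold higher number from compound 1 to compound 3 (0.61 log units; beyond the scatter) is beyond it, so compound 3 stands clearly apart from compound 1 only. Compound 4 `O=C(CSc1nnc(-c2ccncc2)n1-c1ccccc1)N/N=C/c1cc(Br)cc(Br)c1O` differs from compound 3 in one place: 3,5-dibromo-2-hydroxyphenyl in place of 3-fluorophenyl on a carbon with a double bond to nitrogen. The measured steps all change the group on this same carbon and were modest: a 2.5-fold higher number from compound 1 to compound 2 (0.40 log units; beyond the scatter) and a 4.1-fold higher number from compound 1 to compound 3 (0.61 log units; beyond the scatter). Among the compounds with values here, no measured compound carries a hydroxyl or two bromines on that ring, so the direction is uncertain, but a modest move toward a lower number seems most likely since the one bromine-bearing compound 1 gave 5990 nM. Compound 4 is therefore estimated at 9000 nM, a step of a 2.7-fold lower number from compound 3 to compound 4 (0.43 log units; beyond the scatter), with a range from 2500 nM to 30000 nM.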

Compound 4, half-maximal inhibitory concentration: 7590 nM
For compound 4 the middle estimate is 1.2-fold (0.07 log units) above the measured one; low and high end bracket the measured number.
By their numbers in this assay, from the lowest: compounds 1, 4, 2 and 3 (each within the scatter of the next, the first and the last beyond it).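

Within the data shown here, on this carbon with a double bond to nitrogen, 3,5-dibromo-2-hydroxyphenyl brings a hydroxyl and two bromines onto the ring for the first time, and in this assay the change gives a 3.2-fold lower number from compound 3 to compound 4 (0.51 log units; beyond the scatter) and so stands clear of 3-fluorophenyl. It does not stand clear of the other two groups: a 2.0-fold lower number from compound 2 to compound 4 (0.30 log units; within the scatter) and a 1.3-fold higher number from compound 1 to compound 4 (0.10 log units; within the scatter) both lie within the scatter, so this ring shows no clear gain over 4-bromophenyl alone. No evidence is available to explain these numbers. The compounds shown leave open whether the hydroxyl or the bromines account for the step from 3-fluorophenyl, and how an amine or a carboxylic acid on this ring would compare.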